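Piperidin-3-yl in Place of 1-Methylpyrrolidin-3-yl

The compounds below may be only part of what the source reports. "The series", "measured", "known", "first", "only" and "open" are said of these compounds alone.

Compound 1 `CN1CCC(n2cc(S(=O)(=O)c3ccccc3F)c3cccnc32)C1`: 5.6 nM
Compound 2 `CN1CCC(n2cc(S(=O)(=O)c3ccc(Cl)cc3)c3cccnc32)C1`: 4.2 nM

Both numbers come from an assay on HeLa cells for displacement of a labelled ligand from 5-hydroxytryptamine receptor 6 (Homo sapiens); on this read-out lower numbers stand for stronger inhibition and higher numbers for weaker inhibition. Compound 1 and compound 2 lie within the usual scatter of each other, the step being a 1.3-fold lower number from compound 1 to compound 2 (0.12 log units; within the scatter). That change concerns the group on the sulfonyl sulfur only.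

Compound 3 `O=S(=O)(c1ccccc1F)c1cn(C2CCCNC2)c2ncccc12` differs from compound 1 at the aromatic nitrogen instead: piperidin-3-yl in place of 1-methylpyrrolidin-3-yl on an aromatic nitrogen. Going by the values given here, no measured step touches that part of the shared core, so the measured data give no direction for this change. The expected step of a 1.1-fold higher number from compound 1 to compound 3 (0.03 log units; within the scatter) is therefore none beyond the scatter, with a wide range. Compound 3 is expected at 6 nM, between 1.5 nM and 25 nM.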

Compound 3, inhibition constant: 2 nM
The estimate for compound 3 lay 3.0-fold (0.48 log units) above the measured number; the range from low to high includes it.
By their numbers in this assay, from the lowest: compound 3; then compounds 2 and 1 (each within the scatter of the next).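

The group on the aromatic nitrogen matters for this receptor: in this assay, piperidin-3-yl in place of 1-methylpyrrolidin-3-yl gives a 2.8-fold lower number from compound 1 to compound 3 (0.45 log units; beyond the scatter) and, unlike the earlier change on the sulfonyl sulfur, this modest step lies beyond the scatter. The swap changes two things at once, as a five-membered ring becomes a six-membered ring and 0 hydrogen-bond donors become 1. Nothing available here explains the shift.

Pyrrolidin-3-yl and 1-methylpiperidin-3-yl on the same core would show whether ring size or the methyl group carries the step. From the compounds shown here alone, whether the step holds with 4-chlorophenyl on the sulfonyl sulfur also stays open.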